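Shortening the Carbamate Chain to a Cyclopropyl Ring

A few compounds are considered here, and "the series" means these few. Any claim that something is new, unique, unknown or untested is made for them only; others in the source may bear on it.

Three compounds have been measured in an assay on DDT1 cells (Cricetulus griseus) for binding affinity to adenosine receptor A1 (Homo sapiens), read by radioligand binding; on this read-out lower numbers stand for stronger inhibition and higher numbers for weaker inhibition:

Compound 1, `C/N=C(\S)OC[C@H]1OC(n2cnc3c(NC4CCOC4)ncnc32)[C@H](O)[C@@H]1O`: 45 nM
Compound 2, `CCCNC(=O)OC[C@H]1OC(n2cnc3c(NC4CCOC4)ncnc32)[C@H](O)[C@@H]1O`: 235 nM
Compound 3, `CCCCNC(=O)OC[C@H]1OC(n2cnc3c(NC4CCOC4)ncnc32)[C@H](O)[C@@H]1O`: 1410 nM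

Compound 3 stands highest of the three numbers; compound 2 is nearest and compound 1 furthest. Compound 4, `O=C(NC1CC1)OC[C@H]1OC(n2cnc3c(NC4CCOC4)ncnc32)[C@H](O)[C@@H]1O`, differs from compound 3 by cyclopropyl in place of butyl on an amide-type nitrogen. For the measured compounds named here, the steps that bear on this are a 6.0-fold higher number from compound 2 to compound 3 (0.78 log units; beyond the scatter) and a 31-fold higher number from compound 1 to compound 3 (1.50 log units; beyond the scatter), with a 5.2-fold higher number from compound 1 to compound 2 (0.72 log units; beyond the scatter) pointing the same way: each lengthening of the group on the carbamate nitrogen raised the number. Taking a carbon away from that group and closing it into a ring is therefore expected to lower the number, roughly a 9.4-fold lower number from compound 3 to compound 4 (0.97 log units; beyond the scatter). Compound 4 is estimated at 150 nM, within a range from 40 nM to 600 nM.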

Compound 4, inhibition constant: 209 nM
Compound 4: the middle estimate sits 1.4-fold (0.14 log units) below what was measured; measured number inside the range.
By their numbers in this assay, from the lowest: compound 1; then compounds 4 and 2 (each within the scatter of the next); then compound 3.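

In this assay, putting cyclopropyl in place of butyl on the amide-type nitrogen gives a 6.7-fold lower number from compound 3 to compound 4 (0.83 log units; beyond the scatter), and the ring reads level with the propyl chain, with a 1.1-fold lower number from compound 2 to compound 4 (0.05 log units; within the scatter). The ring does not close the remaining gap to the shared core's best number here, with a 4.6-fold higher number from compound 1 to compound 4 (0.67 log units; beyond the scatter) still standing. Nothing measured here explains these steps.
The compounds shown leave open how an ethyl chain or a cyclobutyl ring on that nitrogen would read, and so whether the ring itself matters apart from its carbon count.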